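Replacing the anilide ring with a thiazole in a quinoline ether series

The source may hold more compounds than are shown below. What is called first, only, known or untested is meant among the compounds shown, and "the series" means these compounds.

The measured compounds in a toxicity assay on HepG2 cells (Homo sapiens) for inhibition, read by CellTiter-Glo, with a stated time of 48 h; a higher number here means a weaker inhibitor, a lower number a stronger inhibitor:
Compound 1 `Cc1cc(C)cc(NC(=O)COc2cc(C)nc3ccc(OCc4ccccc4)cc23)c1` gives > 100000 nM, a limit of the assay.
Compound 2 `COc1ccc2nc(C)cc(OCC(=O)Nc3cc(C)c(OC)c(C)c3)c2c1` gives 7940 nM.
Compound 3 `COc1ccc2nc(C)cc(OCC(=O)Nc3cc(C)c(F)c(C)c3)c2c1` gives > 100000 nM, a limit of the assay.

Compound 3 stands at the limit, where (the limit of > 100000 nM in this assay, at which 2 of the 3 values shown sit), so only a bound and no number is known for it. Within the data shown here, the one measured step, an at least 12-fold higher number from compound 2 to compound 3 (1.10 log units; beyond the scatter), concerns a change on the aromatic ring and is large, but it does not touch the part of the molecule that changes next.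

Compound 4 `COc1ccc2nc(C)cc(OCC(=O)Nc3nccs3)c2c1` differs from compound 3 in one place: 1,3-thiazol-2-yl in place of 4-fluoro-3,5-dimethylphenyl on an amide-type nitrogen. No measured step describes an exchange of the whole ring on the amide-type nitrogen, so nothing shown bears directly on it. Among the measured compounds shown here, two of the three values sit at the limit, and compound 2 is the only one with a number.

Given that, compound 4 is expected to stay weak, with a fair chance that it again returns only a limit. Compound 4 is estimated at 60000 nM, in the range 10000 nM to 200000 nM. The step this estimate means, an at least 1.6-fold lower number from compound 3 to compound 4 (0.22 log units; that floor lies within the scatter), is expected to lie within the scatter in either direction.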

Compound 4, half-maximal inhibitory concentration: > 100000 nM
Compound 4: no number, only a limit; the forecaster's own chance of this, stated with the estimate: 60%; middle value at least 1.6-fold (0.22 log units) from the limit.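

In this assay compound 4 gives > 100000 nM, which is a limit of the assay. Among these compounds, compound 3 also stands at a limit, so no step from compound 3 to compound 4 can be read: the limit of > 100000 nM in this assay, at which 3 of the 4 values shown sit. The compounds shown leave open what the 1,3-thiazol-2-yl group does where a number can be measured.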